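The compounds below may be only part of what the source reports. "The series", "measured", "known", "first", "only" and "open" are said of these compounds alone.

Three compounds built on one shared core differ only in the aryl group attached to the amine nitrogen. Compound 1 `CC(C)c1ccc(-c2nc(SCc3cn(CC(=O)NC(=O)Nc4ccccn4)nn3)nc(Nc3ccccc3Cl)c2C#N)cc1` carries a 2-chlorophenyl there, and in a functional assay on MCF7 cells (Homo sapiens) for inhibition, read by MTT assay, with a stated time of 72 h (a lower number here means a stronger inhibitor, a higher number a weaker inhibitor), compound 1 gives 43700 nM. Compound 2 `CC(C)c1ccc(-c2nc(SCc3cn(CC(=O)NC(=O)Nc4ccccn4)nn3)nc(Nc3cccc(Cl)c3)c2C#N)cc1` carries a 3-chlorophenyl instead, and in this assay compound 2 gives 18000 nM, a step described as a 2.4-fold lower number from compound 1 to compound 2 (0.39 log units; beyond the scatter). Compound 3 `CC(C)c1ccc(-c2nc(SCc3cn(CC(=O)NC(=O)Nc4ccccn4)nn3)nc(Nc3ccccc3F)c2C#N)cc1` carries a 2-fluorophenyl. In this assay compound 3 reaches only a limit of the assay, > 64000 nM, so its true number is not known (the limit of > 64000 nM in this assay, at which 1 of the 3 values shown sits). The step of an at least 3.5-fold higher number from compound 2 to compound 3 (0.55 log units; beyond the scatter) is thus at least modest, while an at least 1.4-fold higher number from compound 1 to compound 3 (0.16 log units; that floor lies within the scatter) cannot be separated from scatter.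

Compound 4 `Cc1ccc(Nc2nc(SCc3cn(CC(=O)NC(=O)Nc4ccccn4)nn3)nc(-c3ccc(C(C)C)cc3)c2C#N)cc1` is the next to be tested: 4-methylphenyl in place of 2-fluorophenyl on a nitrogen on an aromatic ring. Within the data shown here, no measured compound carries a methyl on that ring, so the closest guide is that the 3-chlorophenyl of compound 2 gave a lower number than the rings of compound 1 and compound 3, seen in a 2.4-fold lower number from compound 1 to compound 2 (0.39 log units; beyond the scatter) and an at least 3.5-fold higher number from compound 2 to compound 3 (0.55 log units; beyond the scatter). Leaving the 2-fluorophenyl behind is therefore expected to bring a modest decrease, an at least 2.1-fold lower number from compound 3 to compound 4 (0.32 log units; beyond the scatter), although the limit on compound 3 leaves the starting point uncertain. Compound 4 is expected to give about 30000 nM in this assay, somewhere between 8000 nM and 90000 nM.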

Compound 4, half-maximal inhibitory concentration: > 64000 nM
Compound 4: only a limit was reported; the forecaster's own chance of this, stated with the estimate: 35%; middle value at least 2.1-fold (0.32 log units) away from the limit.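

The 4-methylphenyl ring does not keep the lower number seen with the 3-chlorophenyl ring, giving an at least 3.5-fold higher number from compound 2 to compound 4 (0.55 log units; beyond the scatter), so in this small set a methyl-bearing ring on this nitrogen falls clearly short of compound 2. Against the 2-chlorophenyl ring the result is less clear: an at least 1.4-fold higher number from compound 1 to compound 4 (0.16 log units; that floor lies within the scatter) gives only a floor within the scatter, so compound 4 cannot be separated from compound 1 in this assay. The step from compound 3 to compound 4 cannot be read, because the true number of each compound lies somewhere beyond the same limit of the assay: the limit of > 64000 nM in this assay, at which 2 of the 4 values shown sit.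

As far as these compounds go, how far compound 3 and compound 4 lie beyond that limit remains unknown, so the 2-fluorophenyl and 4-methylphenyl rings cannot be ranked against each other. From the compounds shown here alone, it also remains open whether the lower number of compound 2 belongs to chlorine alone, or whether a methoxy group or an amine on this ring could match or lower it.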